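This account rests on a few compounds, and the source may have more. Where it says the series, first, only, none or still open, it means among the compounds named here.

Working notes on the series in a functional assay on CHO cells for agonist activity at Free fatty acid receptor 1 (Homo sapiens), read by FLIPR, tested at 100 nM; on this read-out higher numbers stand for a stronger effect at the one concentration tested and lower numbers for a weaker effect. Among the compounds with values here, compound 1 `CC(Oc1ccccc1F)C(=O)Nc1ccc(OCC(=O)O)c(F)c1` gives 35.1%, compound 2 `CCOc1ccc(OC(C)C(=O)Nc2ccc(OCC(=O)O)c(F)c2)cc1` gives 3.56%, and the one step between compounds differing in a single place, a number 31.5 percentage points lower from compound 1 to compound 2 (beyond the scatter), is the only measured change in the ring on the oxygen on the saturated carbon. Compound 3 `Cc1ccc(C(C)C)cc1OC(C)C(=O)Nc1ccc(OCC(=O)O)c(F)c1` gives 19.4% and stands second highest of the three: compound 1 lies higher and compound 2 lies lower, both gaps beyond the scatter.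

Compound 4 `Cc1ccc(C)c(OC(C)C(=O)Nc2ccc(OCC(=O)O)c(F)c2)c1` differs from compound 3 by methyl in place of isopropyl on an aromatic carbon. Within the data shown here, no measured step swaps one substituent for another on this ring; the step from compound 1 to compound 2 replaced the whole ring, so it bears on compound 4 only as a sign that this ring matters, not as a guide to size or direction. A step of a number 3.4 percentage points lower from compound 3 to compound 4 (within the scatter) is therefore expected, that is, no clear change beyond the scatter. Compound 4 is expected to give about 16%, between 4% and 32%.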

Compound 4, a percentage reported as activity, at one concentration (the size of the read-out at that concentration, not a potency) in the Free fatty acid receptor 1 assay: 18.7%
Beside the measured number, compound 4's estimate is 2.7 percentage points below it; measured number inside the range.
By their numbers in the Free fatty acid receptor 1 assay, from the lowest: compound 2; then compounds 4 and 3 (each within the scatter of the next); then compound 1.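

Within the data shown here, in the Free fatty acid receptor 1 assay, the change of isopropyl to methyl gives a number 0.7 percentage points lower from compound 3 to compound 4 (within the scatter), the first measured change of a single substituent on this ring rather than of the whole ring, and at this place the read-out does not separate the two groups. In a physicochemical assay for lipophilicity, using the shake flask method, at pH 7.4 (a lower number here means a more polar compound, a higher number a more lipophilic compound), compound 3 gives "not determined" (no result reported) and compound 4 gives "not determined" (no result reported), so the change cannot be read there. In the Free fatty acid receptor 1 assay, changing the whole ring still registers, with a number 15.1 percentage points higher from compound 2 to compound 4 (beyond the scatter) on moving from 4-ethoxyphenyl to 2,5-dimethylphenyl and a number 16.4 percentage points lower from compound 1 to compound 4 (beyond the scatter) on moving from 2-fluorophenyl to 2,5-dimethylphenyl. No evidence on hand bears on the reason for these differences.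

Still open, on these data alone, is whether a group of another kind at this aromatic carbon, such as an amine or a trifluoromethyl, would separate from methyl and isopropyl. Also open, as far as these compounds go, is whether a hydrogen there would do so.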